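The compounds below may be only part of what the source reports. "The series", "measured", "known", "first", "only" and "open" are said of these compounds alone.

Measured so far:
Compound 1, `Cc1cccc2cc(S(=O)(=O)NC(=O)Nc3ccc(Cl)cc3)oc12`: 21%
Compound 2, `O=C(Nc1ccc(Cl)cc1)NS(=O)(=O)c1cc2ccccc2o1`: 84%
Compound 3, `Cc1ccc2sc(S(=O)(=O)NC(=O)Nc3ccc(Cl)cc3)cc2c1`: 10%

In a functional assay on the whole organism (Mus musculus) for inhibition, at a dose of 150 mg/kg by the oral route (a higher number here means more inhibition at the dose given (going by the name of the read-out), a lower number less inhibition), compound 2 gives the highest number of the three, and compound 3 gives 10%, the lowest. Among the compounds with values here, the one step measured between two compounds that differ in a single place is a number 63 percentage points higher from compound 1 to compound 2 (beyond the scatter), made by the change (hydrogen in place of methyl on an aromatic carbon). Compound 4, `O=C(Nc1ccc(Cl)cc1)NS(=O)(=O)c1cc2ccccc2s1`, is made from compound 3 by the change (hydrogen in place of methyl on an aromatic carbon). This is the same kind of change as from compound 1 to compound 2, but the place differs: in compound 1 the methyl sits ortho and meta to a fused ring, in compound 3 meta and para. How the core of compound 1 differs from the core of compound 3 is not broken down here. Because of a number 63 percentage points higher from compound 1 to compound 2 (beyond the scatter), a rise is expected for compound 4 as well, though with less certainty. The step expected for compound 4 is a number 40 percentage points higher from compound 3 to compound 4 (beyond the scatter). Compound 4 is therefore estimated at 50%, between 15% and 85%.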

Compound 4, a percentage reported as inhibition, in the whole organism at one dose (the size of the read-out at that dose, not a potency): 47%
Beside the measured number, compound 4's estimate is 3 percentage points above it; the measured number falls inside the stated range.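

In this assay, hydrogen in place of methyl on an aromatic carbon gives a number 37 percentage points higher from compound 3 to compound 4 (beyond the scatter), so the direction of the change holds on a second core. Its size does not carry over: the same change on two cores in this assay, a number 63 percentage points higher (beyond the scatter) from compound 1 to compound 2 and a number 37 percentage points higher (beyond the scatter) from compound 3 to compound 4, 26 percentage points apart, beyond the scatter of two such steps. Two pairs show only that the direction agreed on these two cores, and since both the core and the place of the methyl differ between the pairs, they do not tell which of the two sets the size of the step.

Only methyl and hydrogen appear at these places on the ring. Going by these compounds, what a longer chain, a methoxy group or an amine would do there remains open.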